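Compound 1 and a pyridine-bearing analogue

The compounds below may be only part of what the source reports. "The series", "measured", "known", "first", "only" and "open" are said of these compounds alone.

For the measured compounds named here, compound 1 `NCc1ccc(CN(Cc2nc3ccccc3[nH]2)C2CCCc3cccnc32)c(CN)c1` gives 10 nM in a functional assay on CEM-CCRF cells for antagonist activity at C-X-C chemokine receptor type 4 (Homo sapiens), read by calcium flux (a higher number here means a weaker inhibitor, a lower number a stronger inhibitor), the second highest of the three numbers known. Compound 3 `CO/N=C/c1ccc(CN(Cc2nc3ccccc3[nH]2)C2CCCc3cccnc32)c(CN)c1` gives 5 nM, and the step of a 2.0-fold lower number from compound 1 to compound 3 (0.30 log units; within the scatter) stays within the scatter. Compound 2 `COC(=O)c1ccc(CN(Cc2nc3ccccc3[nH]2)C2CCCc3cccnc32)c(CN)c1` gives 39 nM, and the step of a 3.9-fold higher number from compound 1 to compound 2 (0.59 log units; beyond the scatter) is a modest loss. Compound 4 `NCc1ccncc1CN(Cc1nc2ccccc2[nH]1)C1CCCc2cccnc21` carries a group of 8 heavy atoms (6 carbon, 2 nitrogen; one six-membered aromatic ring with 1 hetero atom) in place of a group of 10 heavy atoms (8 carbon, 2 nitrogen; one six-membered aromatic ring of carbon only), on a saturated chain carbon bound to an amine nitrogen. Going by the values given here, no measured step changes the ring itself; the nearest comparison is the step of a 3.9-fold higher number from compound 1 to compound 2 (0.59 log units; beyond the scatter), in which an aminomethyl on an aromatic carbon was exchanged, so a small loss is the expectation. Compound 4 is therefore estimated at 25 nM, between 8 nM and 80 nM, an expected step of a 2.5-fold higher number from compound 1 to compound 4 (0.40 log units; beyond the scatter).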

Compound 4, half-maximal inhibitory concentration: 160 nM
Compound 4: middle estimate off by 6.4-fold (0.81 log units), on the low side, outside the stated range (above it).
By their numbers in this assay, from the lowest: compounds 3 and 1 (each within the scatter of the next); then compound 2; then compound 4.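

For the compounds shown here, exchanging the whole group on this saturated chain carbon bound to an amine nitrogen matters far more than the exchanges on an aromatic carbon did, with a 16-fold higher number from compound 1 to compound 4 (1.20 log units; beyond the scatter) in this assay standing as a large loss, while the earlier steps were modest or within the scatter. The change alters the ring and removes heavy atoms and a hydrogen-bond donor together, so this step cannot assign the loss to any one of them. No measurement at hand explains the loss.

Going by these compounds, how a hydroxymethyl or a carboxylic acid would behave on the carbon-only ring remains open.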